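The source may hold more compounds than are shown below. What is called first, only, known or untested is meant among the compounds shown, and "the series" means these compounds.

Within the data shown here, compound 1 `COc1ccc(/C=C\C(=O)O)c(OCc2cn(-c3ccccc3C(=O)N3CCC(O)C3)nn2)c1CC=C(C)C` is the only member of this small series with a numerical result: in a functional assay on COLO 205 cells (Homo sapiens) for cytotoxicity, read by MTT assay, with a stated time of 24 h (on this read-out higher numbers stand for weaker inhibition and lower numbers for stronger inhibition), compound 1 gives 25400 nM, which on this read-out is a weak effect. Compound 2 `COc1ccc(-n2cc(COc3c(/C=C\C(=O)O)ccc(OC)c3CC=C(C)C)nn2)cc1` shares the same core but carries a 4-methoxyphenyl on an aromatic nitrogen of the five-membered ring; in this assay compound 2 is recorded as "not determined" (no result reported), so it cannot be placed among the other values. Compound 3 `COc1ccc(/C=C\C(=O)O)c(OCc2cn(-c3ccccc3F)nn2)c1CC=C(C)C` differs from compound 2 in one place: 2-fluorophenyl in place of 4-methoxyphenyl on an aromatic nitrogen. Among the measured compounds shown here, no measured step exists for this change, and the only anchor is the weak result of compound 1. For the measured compounds named here, with no counterpart measured for compound 2, a step of any size or direction beyond the scatter cannot be supported for compound 3, and the expectation rests on compound 1 alone. Compound 3 is expected to give about 20000 nM in this assay, with a plausible range from 5000 nM to 80000 nM.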

Compound 3, half-maximal inhibitory concentration: 14500 nM
The estimate for compound 3 lay 1.4-fold (0.14 log units) above the measured number; low and high end bracket the measured number.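

In this assay, fluoro in place of (3-hydroxypyrrolidin-1-yl)carbonyl on an aromatic carbon gives a 1.8-fold lower number from compound 1 to compound 3 (0.24 log units; within the scatter), so this position takes either group with no change that the read-out can separate from scatter. The step from compound 2 to compound 3 cannot be read, as compound 2 has no number. Nothing available explains why these two groups read alike.

As far as these compounds go, it stays open whether an amine or a carboxylic acid on this phenyl ring, or an unsubstituted phenyl, would move the number beyond the scatter. From the compounds shown here alone, the effect of the 4-methoxyphenyl of compound 2 also remains unknown, so the series still offers no substituent that departs from the range set by compound 1 and compound 3.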